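This account rests on a few compounds, and the source may have more. Where it says the series, first, only, none or still open, it means among the compounds named here.

Compound 1 (`CCOC(=O)[C@@H]1[C@@H](C(=O)OCC)N1C(=O)[C@@H]1CCCN(C(=O)[C@H](CC(C)C)NC(=O)OC(C)(C)C)C1`) gives > 100000 nM in a functional assay on J774 cells (Mus musculus) for cytotoxicity, with a stated time of 48 h (a higher number here means a weaker inhibitor, a lower number a stronger inhibitor), a limit of the assay and not a number. Compound 2 (`CCOC(=O)[C@@H]1[C@@H](C(=O)OCC)N1C(=O)[C@H]1CCCN(C(=O)[C@H](CC(C)C)NC(=O)OC(C)(C)C)C1`) gives > 100000 nM, again a limit. Compound 3 (`CCOC(=O)[C@H]1[C@H](C(=O)OCC)N1C(=O)[C@@H]1CCCN(C(=O)[C@H](CC(C)C)NC(=O)OC(C)(C)C)C1`) gives > 100000 nM, which is also a limit. Compound 3 therefore holds no readable position of its own, and the series sits at the limit of > 100000 nM in this assay, at which 3 of the 3 values shown sit.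

Compound 4 (`CCOC(=O)[C@H]1[C@H](C(=O)OCC)N1C(=O)[C@H]1CCCN(C(=O)[C@H](CC(C)C)NC(=O)OC(C)(C)C)C1`) has not yet been measured. It relates to compound 3 as follows: the two compounds have the same atoms and bonds and differ only in configuration as drawn: 1 of 4 stereo elements differ; a stereocentre at a saturated ring carbon is drawn R in compound 3 and S in compound 4. Going by the values given here, the closest precedent is a step that the two limits leave unreadable from compound 1 to compound 2, which is likewise a change from R to S at a saturated ring carbon. The other two comparisons, a step that the two limits leave unreadable from compound 1 to compound 3 and a step that the two limits leave unreadable from compound 2 to compound 3, also involve configuration alone. None of the three gives a size, yet no configuration tested so far has produced a number in this assay. No step beyond the scatter is therefore expected, and no direction can be named, so the expected change is a number no higher from compound 3 to compound 4 (the limit leaves the size open). For compound 4 the estimated value is 100000 nM, with an expected range from 50000 nM to 200000 nM.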

Compound 4, half-maximal inhibitory concentration: > 100000 nM
Compound 4: a limit, no number; the forecaster's own chance of this, stated with the estimate: 90%; the middle value lies on the limit itself.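

Compound 4, like compounds 1, 2 and 3, gives only a limit in this assay, so no step between any of these compounds can be read. The compounds shown leave open whether any configuration differs in cytotoxicity, since all four sit at that limit: the limit of > 100000 nM in this assay, at which 4 of the 4 values shown sit.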